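Working notes: from compound 3 to compound 4

The source may hold more compounds than are shown below. What is called first, only, known or untested is meant among the compounds shown, and "the series" means these compounds.

Measured so far in a functional assay on HepG2 cells (Homo sapiens) for antiproliferative activity, read by sulforhodamine B assay, with a stated time of 48 h (a higher number here means a weaker inhibitor, a lower number a stronger inhibitor), for these compounds:
compound 1 (`COc1ccc(C=C(C(=O)/C=C/c2cccc(OC)c2OC)C(=O)/C=C/c2cccc(OC)c2OC)cc1OC`) gives 200 nM in this series
compound 2 (`COc1ccc(/C=C/C(=O)C(=Cc2ccc(O)c(OC)c2)C(=O)/C=C/c2ccc(OC)cc2OC)c(OC)c1`) gives 510 nM in this series
compound 3 (`COc1ccc(/C=C/C(=O)C(=Cc2ccc(O)c(F)c2)C(=O)/C=C/c2ccc(OC)cc2OC)c(OC)c1`) gives 1760 nM in this series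

Compound 3 stands at 1760 nM as the highest number of the three. Compound 4 (`COc1ccc(/C=C/C(=O)C(=Cc2cc(Br)c(O)c(OC)c2)C(=O)/C=C/c2ccc(OC)cc2OC)c(OC)c1`) brings 3-bromo-4-hydroxy-5-methoxyphenyl in place of 3-fluoro-4-hydroxyphenyl on a double-bonded chain carbon bound to a double-bonded chain carbon with 3-bromo-4-hydroxy-5-methoxyphenyl in place of 3-fluoro-4-hydroxyphenyl on a double-bonded chain carbon bound to a double-bonded chain carbon. Going by the values given here, one measured step bears on this: a 3.5-fold higher number from compound 2 to compound 3 (0.54 log units; beyond the scatter) for fluoro in place of methoxy on an aromatic carbon. Among the compounds with values here, compound 4 carries methoxy again and loses the fluoro, so a step of similar size in the opposite direction is expected in this assay although no bromo compound has been measured. The estimated move is a 2.3-fold lower number from compound 3 to compound 4 (0.37 log units; beyond the scatter) toward a lower number. Compound 4 is expected at 750 nM (estimated range 250 nM to 2200 nM).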

Compound 4, half-maximal inhibitory concentration: 1190 nM
Compound 4: the middle estimate sits 1.6-fold (0.20 log units) below what was measured; the measured number falls inside the stated range.
By their numbers in this assay, from the lowest: compound 1; then compound 2; then compounds 4 and 3 (each within the scatter of the next).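

In this assay, replacing 3-fluoro-4-hydroxyphenyl with 3-bromo-4-hydroxy-5-methoxyphenyl gives a 1.5-fold lower number from compound 3 to compound 4 (0.17 log units; within the scatter), so this exchange on a double-bonded chain carbon does not separate the two compounds. The more informative reading is against the non-halogenated parent, where bromo in place of hydrogen on an aromatic carbon gives a 2.3-fold higher number from compound 2 to compound 4 (0.37 log units; beyond the scatter), showing that this ring is sensitive to an added halogen even when its methoxy is kept, and not only to the loss of methoxy seen with the fluoro exchange. Nothing available gives a cause for either shift.

Still open, as far as these compounds go, is whether chloro or an amine in place of the bromo would also raise the number relative to compound 2. Also open, from the compounds shown here alone, is whether bromo would have a similar effect on the core of compound 1.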